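The source may hold more compounds than are shown below. What is called first, only, known or untested is meant among the compounds shown, and "the series" means these compounds.

Measured compounds in an assay on HEK293 cells for positive allosteric modulation of metabotropic glutamate receptor 3 (Rattus norvegicus), read by thallium flux, with a stated time of 2.5 min; on this read-out higher numbers stand for larger maximal responses and lower numbers for smaller maximal responses:
compound 1 `Cc1cc(C(=O)O)ccc1OCCCCOc1ccc(C(=O)CC(C)C)c(O)c1C`: 42.1%
compound 2 `Cc1c(OCCCCOc2ccc(C(=O)O)cc2Cl)ccc(C(=O)CC(C)C)c1O`: 62.9%

In this assay, among the measured compounds shown here, compound 1 gives 42.1%, the lower of the two numbers; the only measured step in the set runs a number 20.8 percentage points higher from compound 1 to compound 2 (beyond the scatter), a chloro in place of methyl on an aromatic carbon.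

Compound 3 `Cc1cc(C(=O)O)ccc1OCCCCOc1ccc(C(=O)C(C)C)c(O)c1C` is not yet measured. It differs from compound 1 by isopropyl in place of isobutyl on a carbonyl carbon, so the change sits on the carbonyl carbon and not on an aromatic carbon. For the measured compounds named here, the single measured step concerns a different position and a different kind of group, so no measured step bears on this change, and the two measured values give no guide to the effect of shortening the chain on the carbonyl.

With nothing to anchor a direction, the expected step is a number 0.1 percentage points lower from compound 1 to compound 3 (within the scatter), none beyond the scatter. Compound 3 is therefore estimated at 42% in this assay, expected to fall between 25% and 60%.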

Compound 3, largest response reached (reported as percent of maximum), in percent of the reference or control that the assay uses: 25.2%
For compound 3 the middle estimate is 16.8 percentage points above the measured one, and the stated range covers the measured number.
By their numbers in this assay, from the lowest: compound 3; then compound 1; then compound 2.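

On the carbonyl carbon the substituent is not neutral in this assay: isopropyl in place of isobutyl gives a change beyond the usual scatter (a number 16.9 percentage points lower from compound 1 to compound 3 (beyond the scatter)), so this site also moves the maximal response, which the earlier aromatic change could not show. With this result, the series has two positions at which a single change shifts the response, and compound 3 holds the lowest number of the three compounds. Nothing available here accounts for the drop on going from isobutyl to isopropyl.

The compounds shown leave open whether a longer chain, such as n-pentyl, or a cyclopropyl group on the carbonyl carbon would carry the response further in either direction. They also leave open whether chloro in place of methyl on the aromatic carbon gives a similar step when isopropyl sits on the carbonyl carbon.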